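Replacing Amino with Pyridin-3-yl on Compound 2

The compounds below may be only part of what the source reports. "The series", "measured", "known", "first", "only" and "open" are said of these compounds alone.

Compound 1 `CC(=O)Nc1ccc(-c2nnc(C3(c4ccc(Cl)cc4)CCC3)n2C)c(Cl)c1` sits at a limit of the assay in an assay on isolated protein for inhibition of 11-beta-hydroxysteroid dehydrogenase type 2 (Homo sapiens) (on this read-out higher numbers stand for weaker inhibition and lower numbers for stronger inhibition), where compound 1 gives > 4000 nM. Compound 3 `Cc1noc(C)c1-c1ccc(-c2nnc(C3(c4ccc(Cl)cc4)CCC3)n2C)cc1` likewise sits at a limit in this assay, where compound 3 gives > 4000 nM. Within the data shown here, compound 2 `Cn1c(-c2ccc(N)cc2Cl)nnc1C1(c2ccc(Cl)cc2)CCC1` is the only compound with a number in this assay, where compound 2 gives 2300 nM. The change of hydrogen in place of acetyl on a nitrogen on an aromatic ring gives an at least 1.7-fold lower number from compound 1 to compound 2 (0.24 log units; that floor lies within the scatter). Compound 4 `Cn1c(-c2ccc(-c3cccnc3)cc2Cl)nnc1C1(c2ccc(Cl)cc2)CCC1` differs from compound 2 by pyridin-3-yl in place of amino on an aromatic carbon. Among the measured compounds shown here, only the step from compound 1 to compound 2 bears on this place, and it stays within the scatter, so no step beyond the scatter is expected in either direction. Compound 4 is therefore estimated at 2500 nM, between 800 nM and 8000 nM, an expected step of a 1.1-fold higher number from compound 2 to compound 4 (0.04 log units; within the scatter).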

Compound 4, half-maximal inhibitory concentration: > 4000 nM
Compound 4: a limit, no number; the forecaster's own chance of this, stated with the estimate: 45%; at least 1.6-fold (0.20 log units) between middle value and limit.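

In this assay compound 4 gives > 4000 nM, which is a limit and not a number. Pyridin-3-yl in place of amino on this aromatic carbon gives an at least 1.7-fold higher number from compound 2 to compound 4 (0.24 log units; that floor lies within the scatter), so this ring does not yield a measurable number here, and compound 2 remains the only compound with one. The step from compound 1 to compound 4 cannot be read, as both values are limits.

On these data alone, how far the values of compound 1, compound 3 and compound 4 lie from the measured range stays open, with the readings confined to: the limit of > 4000 nM in this assay, at which 3 of the 4 values shown sit. Also open is whether a methylamino group or a carboxylic acid on this aromatic carbon would give a number in this assay.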